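The source may report more compounds than this note shows. Statements on the series, on what has been measured and on what is new or still open speak of the compounds shown alone.

Of the compounds shown here, two sharing one core have been measured in a functional assay on MGC-803 cells (Homo sapiens) for antiproliferative activity, read by MTT assay, with a stated time of 48 h; a higher number here means a weaker inhibitor, a lower number a stronger inhibitor. Compound 1, `O=C(Nc1cccc(CNc2nccnc2Cl)c1)Nc1cccc2ccccc12`, carries a naphthyl group on one urea nitrogen, and in this assay compound 1 gives 32700 nM. Compound 2, `CCOc1ccc(NC(=O)Nc2cccc(CNc3nccnc3Cl)c2)cc1`, carries a 4-ethoxyphenyl group at the same position instead, and in this assay compound 2 gives 7240 nM. Of the two numbers, that of compound 2 is the lower, and the gap to compound 1 lies beyond the usual scatter, so compound 2 is the stronger inhibitor of the pair.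

Compound 3, `O=C(Nc1cccc(CNc2nccnc2Cl)c1)NC1CCCCC1`, is the next step from compound 2. The change is cyclohexyl in place of 4-ethoxyphenyl on an amide-type nitrogen. Within the data shown here, no measured pair shows what such a change does here, so the expectation rests on the two values alone. A small step is expected, if any, likely toward a weaker inhibitor, so that the estimated step of a 1.7-fold higher number from compound 2 to compound 3 (0.22 log units; within the scatter) may not exceed the scatter. Compound 3 is estimated at 12000 nM, within a range from 3500 nM to 40000 nM.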

Compound 3, half-maximal inhibitory concentration: > 40000 nM
Compound 3 was reported as a limit; the forecaster's own chance of this, stated with the estimate: 10%; middle value at least 3.3-fold (0.52 log units) from the limit.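

In this assay compound 3 gives > 40000 nM, which is a limit of the assay and not a number. Cyclohexyl in place of 4-ethoxyphenyl on the amide-type nitrogen gives an at least 5.5-fold higher number from compound 2 to compound 3 (0.74 log units; beyond the scatter), so this position does not treat these two six-membered rings alike, and the change weakens the compound clearly rather than slightly. The full size of the step cannot be read, and the printed figure is only its lower bound: the limit of > 40000 nM in this assay, at which 1 of the 3 values shown sits.

The compounds shown leave open whether the aromatic ring or the ethoxy group accounts for the difference, for this change replaces both at once. A plain phenyl group on the same nitrogen would help to separate the two, as would a cyclohexyl ring carrying an ethoxy group.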